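The source may hold more compounds than are shown below. What is called first, only, known or untested is meant among the compounds shown, and "the series" means these compounds.

Of the compounds shown here, three have been measured in a functional assay on HepG2 cells (Homo sapiens) for cytotoxicity; a higher number here means a weaker inhibitor, a lower number a stronger inhibitor. Compound 1 `CC1C(=O)N(CCCCCCOc2ccc(Cl)cc2)/C(=N\C#N)N1c1ccncc1` gives 282 nM, compound 2 `CCC1C(=O)N(CCCCCCOc2ccc(Cl)cc2)/C(=N\C#N)N1c1ccncc1` gives 4350 nM, and compound 3 `N#C/N=C1\N(CCCCCOc2ccc(Cl)cc2)C(=O)C(c2ccccc2)N1c1ccncc1` gives 415 nM. Compound 3 stands second highest of the three numbers: compound 1 is nearest, within the scatter, while compound 2 lies furthest away, beyond it. Among the measured compounds shown here, the single step between measured compounds, a 15-fold higher number from compound 1 to compound 2 (1.19 log units; beyond the scatter), concerns a different place on the shared core. Compound 4 `N#C/N=C1\N(CCCCCCOc2ccc(Cl)cc2)C(=O)C(c2ccccc2)N1c1ccncc1` differs from compound 3 in one place: (4-chlorophenoxy)methyl in place of 4-chlorophenoxy on a saturated chain carbon, five bonds along the chain from an amide-type nitrogen in a ring. For the measured compounds named here, no measured step bears on this change, so the expected step is no change at the digits printed from compound 3 to compound 4 (within the scatter), none beyond the scatter. Compound 4 is therefore estimated at 415 nM in this assay, with a range from 140 nM to 1250 nM.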

Compound 4, half-maximal inhibitory concentration: 44 nM
For compound 4 the middle estimate is 9.4-fold (0.97 log units) above the measured one; the whole stated range lies above it.
By their numbers in this assay, from the lowest: compound 4; then compounds 1 and 3 (each within the scatter of the next); then compound 2.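

In this assay the chain carbon is not a neutral place, since (4-chlorophenoxy)methyl in place of 4-chlorophenoxy gives a 9.4-fold lower number from compound 3 to compound 4 (0.97 log units; beyond the scatter) and so the chain count alone moves the number beyond the scatter. With this chain, phenyl on the saturated ring carbon in place of ethyl gives a 99-fold lower number from compound 2 to compound 4 (2.00 log units; beyond the scatter) and in place of methyl gives a 6.4-fold lower number from compound 1 to compound 4 (0.81 log units; beyond the scatter) and thus the lowest number of the three groups there. Nothing at hand explains these steps. From the compounds shown here alone, it remains open whether a longer chain, such as one ending in 3-(4-chlorophenoxy)propyl, would lower the number further. Going by these compounds, whether benzyl on the ring carbon would match phenyl also stays open.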